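The source may hold more compounds than are shown below. What is called first, only, known or untested is meant among the compounds shown, and "the series" means these compounds.

Compound 1 `CCOc1ccc(-c2cc(=O)c3c(o2)C(CC)(CC)C(=O)C(CC)=C3O)cc1` is tested in a functional assay on KB cells (Homo sapiens) for antiproliferative activity, read by sulforhodamine B assay, with a stated time of 3 days; on this read-out lower numbers stand for an effect already at smaller amounts and higher numbers for an effect only at larger amounts of compound. In this assay compound 1 reaches only a limit of > 52.4 uM. The step to compound 4 `CCC1=C(O)c2c(oc(-c3ccc(C)c(C)c3)cc2=O)C(CC)(CC)C1=O` is 3,4-dimethylphenyl in place of 4-ethoxyphenyl on an aromatic carbon. Going by the values given here, no measured step alters the same group. Among the compounds with values here, the one step recorded, an at least 1.3-fold higher number from compound 2 to compound 3 (0.12 log units; that floor lies within the scatter), lies within the scatter and concerns another pair. Compound 2 `CCC1=C(O)c2c(oc(-c3cccc(C(F)(F)F)c3)cc2=O)C(CC)(CC)C1=O` gives 35.7 uM in this assay. For compound 3 `CCC1=C(O)c2c(oc(-c3cccc(OC(F)(F)F)c3)cc2=O)C(CC)(CC)C1=O` this assay shows only a limit of > 47.4 uM. Limits are common among these values: the limit of > 52.4 uM in this assay, at which 1 of the 3 values shown sits, and (the limit of > 47.4 uM in this assay, at which 1 of the 3 values shown sits). Compound 4 is therefore expected to remain weak, and its step from compound 1 is estimated at an at least 1.1-fold lower number from compound 1 to compound 4 (0.06 log units; that floor lies within the scatter). Compound 4 is expected to give about 45 uM, between 20 uM and 100 uM.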

Compound 4, concentration for half-maximal effect: 35.5 uM
Beside the measured number, compound 4's estimate is 1.3-fold (0.10 log units) above it, and the stated range covers the measured number.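

At this position, on an aromatic carbon next to the ring oxygen, 3,4-dimethylphenyl in place of 4-ethoxyphenyl gives an at least 1.4-fold lower number from compound 1 to compound 4 (0.16 log units; that floor lies within the scatter) in this assay. So this swap, which removes the ether oxygen, shows no change beyond the scatter. The step is only a floor because the value for compound 1 is a limit: the limit of > 52.4 uM in this assay, at which 1 of the 4 values shown sits.

Going by these compounds, its true size stays open, and so does whether the lost oxygen or the added methyl groups matter more, since both change together. The compounds shown also leave open how an amine or a carboxylic acid on this phenyl ring would read.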